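Aortic relaxation series: working notes toward compound 4

The compounds below may be only part of what the source reports. "The series", "measured", "known", "first", "only" and "open" are said of these compounds alone.

Measured so far, in a functional assay (aorta) with Rattus norvegicus as the target; on this read-out higher numbers stand for an effect only at larger amounts of compound and lower numbers for an effect already at smaller amounts:
- compound 1 `COc1ccc(-c2nc(/N=C(\N)N(C)C)sc2-c2ccc(OC)cc2)cc1` gives 4.8 uM
- compound 2 `COc1ccc(-c2nc(/N=C(\N)[N+]3(C)CCCCC3)sc2-c2ccc(OC)cc2)cc1` gives 21 uM
- compound 3 `COc1ccc(-c2nc(CNC(=O)CSC)sc2-c2ccc(OC)cc2)cc1` gives 6 uM

Among the compounds with values here, compound 1 has the lowest number of the three; compound 3 sits within the scatter of it, while a 4.4-fold higher number from compound 1 to compound 2 (0.64 log units; beyond the scatter) is the only step beyond the scatter.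

Compound 4 `CCOC(=O)/C(C#N)=C/c1nc(-c2ccc(OC)cc2)c(-c2ccc(OC)cc2)s1` differs from compound 1 as follows: a group of 9 heavy atoms (6 carbon, 1 nitrogen, 2 oxygen; no ring) in place of a group of 6 heavy atoms (3 carbon, 3 nitrogen; no ring), on an aromatic carbon. Within the data shown here, the closest precedent is the exchange of the same group at the same aromatic carbon, where a 1.3-fold higher number from compound 1 to compound 3 (0.10 log units; within the scatter). The exchange is therefore expected to cost little or nothing beyond the scatter, with a modest upward drift allowed given a 4.4-fold higher number from compound 1 to compound 2 (0.64 log units; beyond the scatter). For compound 4 the expected step is a 1.7-fold higher number from compound 1 to compound 4 (0.22 log units; within the scatter), and the estimated value is 8 uM within 3 uM to 25 uM.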

Compound 4, concentration for half-maximal effect: > 100 uM
Compound 4 ended at the assay's limit; the forecaster's own chance of this, stated with the estimate: 10%; at least 12-fold (1.09 log units) between middle value and limit.
By their numbers in this assay, from the lowest: compounds 1 and 3 (each within the scatter of the next); then compound 2. At a limit, above all of these: compound 4.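

In this assay compound 4 sits at a limit, not at a number: the limit of > 100 uM in this assay, at which 1 of the 4 values shown sits.

This aromatic carbon, next to the ring nitrogen and the ring sulfur, does not accept every group: with 2-cyano-2-(ethoxycarbonyl)ethenyl the step is an at least 20-fold higher number from compound 1 to compound 4 (1.31 log units; beyond the scatter), and against the side chain of compound 3 it is an at least 16-fold higher number from compound 3 to compound 4 (1.22 log units; beyond the scatter). The change also goes past the cationic piperidinium compound, with an at least 4.7-fold higher number from compound 2 to compound 4 (0.67 log units; beyond the scatter).

Which part of the entering group goes with the loss remains open, whether the nitrile, the ester or the double bond. Also open, on these data alone, is where a carboxylic acid or a simple primary amine on this carbon would fall.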